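Indole nitrogen substitution on the fused thiazolo core

The source may hold more compounds than are shown below. What is called first, only, known or untested is meant among the compounds shown, and "the series" means these compounds.

Compound 1 `O=C(c1ccn2c1CSC2c1cccnc1)c1c[nH]c2cc(-c3ccc(F)cc3)ccc12` carries a free indole nitrogen and a 4-fluorophenyl group; in a functional assay (Oryctolagus cuniculus) for antagonist activity at platelet-activating factor receptor (Cavia porcellus) (on this read-out higher numbers stand for weaker inhibition and lower numbers for stronger inhibition), compound 1 gives 75 nM, the second highest of the three numbers and within the scatter of compound 2 `CN(C)C(=O)n1cc(C(=O)c2ccn3c2CSC3c2cccnc2)c2ccccc21`, which gives 95 nM. Compound 3 `CN(C)C(=O)n1cc(C(=O)c2ccn3c2CSC3c2cccnc2)c2ccc(Sc3ccc(F)cc3)cc21` gives 17 nM, and the number of compound 1 lies beyond the scatter above that of compound 3. Compound 4 `CN(C)C(=O)Cn1cc(C(=O)c2ccn3c2CSC3c2cccnc2)c2ccc(-c3ccc(F)cc3)cc21` differs from compound 1 by (dimethylcarbamoyl)methyl in place of hydrogen on an aromatic nitrogen. Among the measured compounds shown here, no measured step changes the indole nitrogen alone. For the measured compounds named here, the one measured step, a 5.6-fold lower number from compound 2 to compound 3 (0.75 log units; beyond the scatter), concerns a different position and is only a background reference; compounds 2 and 3 both carry a group on that nitrogen, and compound 3 also carries an aryl-type group on the benzo ring and shows the lowest number of the three. Given no direct precedent, a change within the scatter or a modest step to a lower number is expected for compound 4, as a 1.9-fold lower number from compound 1 to compound 4 (0.27 log units; within the scatter). Compound 4 is estimated at 40 nM, with a range from 12 nM to 130 nM.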

Compound 4, inhibition constant: 0.7 nM
Beside the measured number, compound 4's estimate is 57-fold (1.76 log units) above it; measured number outside the range, below it.
By their numbers in this assay, from the lowest: compound 4; then compound 3; then compounds 1 and 2 (each within the scatter of the next).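

In this assay, among the compounds shown here, the aromatic nitrogen of the five-membered ring proves highly responsive: (dimethylcarbamoyl)methyl in place of hydrogen gives a 110-fold lower number from compound 1 to compound 4 (2.03 log units; beyond the scatter) and is the only measured change at this place. The earlier compounds shown here offered only a 5.6-fold lower number from compound 2 to compound 3 (0.75 log units; beyond the scatter) at a different place, while compounds 2 and 3 differ from compound 4 in more than one place and give no direct reading of this nitrogen. Nothing at hand accounts for the size of the new step.

As far as these compounds go, it remains open whether a plain methyl, a longer chain, a carboxylic acid or an amine on this nitrogen would give a step of similar size. From the compounds shown here alone, the step is also read only with the 4-fluorophenyl group present, and whether it carries over to compounds without that group is unknown.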